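Two Paired Lactone Compounds and One Added Acetyl

A few compounds are considered here, and "the series" means these few. Any claim that something is new, unique, unknown or untested is made for them only; others in the source may bear on it.

Measured compounds:
- compound 1 (`O=C1C=CC[C@@H]([C@H](O)[C@H](O[C@@H](c2ccccc2)[C@@H](O)[C@@H]2CC=CC(=O)O2)c2ccccc2)O1`) gives 5900 nM in the test described below
- compound 2 (`O=C1C=CC[C@@H]([C@H](O)[C@@H](O[C@H]([C@@H]2CC=CC(=O)O2)[C@@H](O)c2ccccc2)c2ccccc2)O1`) gives 8000 nM in the same test

Both values come from a functional assay on HCT-116 cells (Homo sapiens) for cytotoxicity, read by luminescence and CellTiter-Glo, with a stated time of 72 h (a lower number here means a stronger inhibitor, a higher number a weaker inhibitor), and lie within the usual scatter of each other. Compound 1 therefore stands level with compound 2, and the two cannot be ranked. Neither is a clear reference point for stronger or weaker activity, and the pair differs in more than one place, so it offers no guide to a single structural change.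

Compound 3 (`CC(=O)O[C@@H]([C@@H]1CC=CC(=O)O1)[C@H](O[C@@H](c1ccccc1)[C@@H](O)[C@@H]1CC=CC(=O)O1)c1ccccc1`) has not yet been measured. It departs from compound 1 in one place (acetyl in place of hydrogen on an oxygen on a saturated carbon), with acetyl in place of hydrogen on an oxygen on a saturated carbon, which reads as hydroxy to acetoxy. For the measured compounds named here, no measured step shows what this change does, so only a modest shift is expected in this assay, leaning towards a lower number but not beyond the scatter. The expected change is a 1.5-fold lower number from compound 1 to compound 3 (0.17 log units; within the scatter) and remains uncertain. Compound 3 is estimated to give 4000 nM in this measurement, with an expected range (1200 nM to 12000 nM).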

Compound 3, half-maximal inhibitory concentration: 4100 nM
Compound 3: the middle estimate sits 1.0-fold (0.01 log units) below what was measured, and the stated range covers the measured number.
By their numbers in this assay, from the lowest: compounds 3, 1 and 2 (each within the scatter of the next).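

In this assay, for the compounds shown here, acetyl in place of hydrogen on an oxygen on a saturated carbon gives a 1.4-fold lower number from compound 1 to compound 3 (0.16 log units; within the scatter), and this is the only step in the set that isolates a single change. It shows that the hydroxy at this position can become acetoxy without a shift beyond the scatter, so the hydrogen on this oxygen is not required for the level of cytotoxicity seen with compound 1. No accompanying data bear on why this step is so small.

The compounds shown leave open whether a methyl ether or a longer acyl chain, such as butyryl, on this oxygen would also stay within the scatter, and whether an amine in place of the hydroxy would move the number beyond it. They also leave open whether acetyl on the remaining hydroxy of compound 3, or the same hydroxy-to-acetoxy change on compound 2, would give a step of similar size.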